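Vero cytotoxicity in the aryl-substituted dihydropyrimidinone amide series

The compounds below may be only part of what the source reports. "The series", "measured", "known", "first", "only" and "open" are said of these compounds alone.

Measured so far:
compound 1 `CC1=C(C(=O)Nc2ccccc2Cl)C(c2ccccc2Br)NC(=O)N1`: > 100000 nM
compound 2 `CC1=C(C(=O)Nc2ccccc2Cl)C(c2cccc(Br)c2)NC(=O)N1`: > 100000 nM

In an ADME assay on Vero cells (Chlorocebus sabaeus) for cytotoxicity, read by XTT assay, with a stated time of 72 h (a lower number here means that less compound is tolerated, a higher number that more compound is tolerated), compound 1 gives > 100000 nM, which is a limit of the assay and not a number. Compound 2 gives > 100000 nM, likewise a limit. Within the data shown here, compound 1 therefore stands only at a limit, and the one further value in hand is a limit as well (the limit of > 100000 nM in this assay, at which 2 of the 2 values shown sit). The step that the two limits leave unreadable from compound 1 to compound 2 is left unreadable by the two limits.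

Compound 3 `COc1ccc(C2NC(=O)NC(C)=C2C(=O)Nc2ccccc2Cl)cc1` differs from compound 1 in 4-methoxyphenyl in place of 2-bromophenyl on a saturated ring carbon. Among the measured compounds shown here, the only measured step concerns the same saturated ring carbon, but its size is unreadable, and no measured step touches the 4-methoxyphenyl. No step beyond the scatter in this assay can be derived from the data. Compound 3 is expected to give 150000 nM, in the range 60000 nM to 400000 nM, most likely reported again only as a limit. The step that the limit leaves unreadable from compound 1 to compound 3 is expected to be small.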

Compound 3, half-maximal cytotoxic concentration: > 100000 nM
Compound 3: no number, only a limit; the forecaster's own chance of this, stated with the estimate: 80%; the middle value does not contradict the limit.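

In this assay, no new step can be read among compound 1, compound 2 and compound 3, because all three stand at the same limit: the limit of > 100000 nM in this assay, at which 3 of the 3 values shown sit.

The compounds shown leave open whether any aryl group on the saturated ring carbon gives a readable half-maximal cytotoxic concentration.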